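Swapping the Sulfur-Bound Chain in a Chalcone Series

This account rests on a few compounds, and the source may have more. Where it says the series, first, only, none or still open, it means among the compounds named here.

Measured compounds:
compound 1, `Cc1cc(Nc2ccc(C(=O)/C=C/c3cccc(Br)n3)cc2)n2nc(SCc3ccc(Br)cc3)nc2n1`, 96.3%
compound 2, `Cc1cc(Nc2ccc(C(=O)/C=C/c3cccc(Br)n3)cc2)n2nc(SCc3ccccc3[N+](=O)[O-])nc2n1`, 92.3%
compound 3, `Cc1cc(Nc2ccc(C(=O)/C=C/c3cccc(Br)n3)cc2)n2nc(SCCCc3ccccc3)nc2n1`, 76.7%

In a functional assay on MGC-803 cells (Homo sapiens) for inhibition, read by sulforhodamine B assay, with a stated time of 72 h, tested at 10 uM (a lower number here means less inhibition, a higher number more inhibition at the concentration tested (going by the name of the read-out)), compound 3 gives the lowest of the three numbers; its nearest neighbour is compound 2, with a number 15.6 percentage points lower from compound 2 to compound 3 (beyond the scatter), and the furthest is compound 1, with a number 19.6 percentage points lower from compound 1 to compound 3 (beyond the scatter). Compound 4, `C#CCSc1nc2nc(C)cc(Nc3ccc(C(=O)/C=C/c4cccc(Br)n4)cc3)n2n1`, alters the same place: ethynyl in place of phenethyl on a saturated chain carbon bound to a sulfur. Among the measured compounds shown here, the two steps bearing on this position were both modest, so only a modest step is expected in this assay, and its direction is uncertain since no measured step reaches ethynyl. The estimate for compound 4 is 72%, between 50% and 92%, which is expected to amount to a number 4.7 percentage points lower from compound 3 to compound 4 (within the scatter).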

Compound 4, a percentage reported as inhibition, at one concentration (the size of the read-out at that concentration, not a potency): 94.4%
Compound 4: middle estimate off by 22.4 percentage points, on the low side; the whole stated range lies below it.
By their numbers in this assay, from the lowest: compound 3; then compounds 2, 4 and 1 (each within the scatter of the next).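

In this assay, a phenyl ring on this chain is not required for a high number: ethynyl, with no ring, restores the level lost with phenethyl (a number 17.7 percentage points higher from compound 3 to compound 4 (beyond the scatter)) and sits with the ring-bearing groups (a number 2.1 percentage points higher from compound 2 to compound 4 (within the scatter); a number 1.9 percentage points lower from compound 1 to compound 4 (within the scatter)). Among these compounds, only the phenethyl group of compound 3 stands apart. No available evidence explains this difference. Still open, going by these compounds, is whether a longer chain ending in ethynyl, or an amine or carboxylic acid at this place, would keep the number in this assay at that level.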